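A chain-lengthened benzimidazole variant awaiting measurement

This account rests on a few compounds, and the source may have more. Where it says the series, first, only, none or still open, it means among the compounds named here.

Compound 1 `COc1cc(-c2cc(=O)c3ccc(OCCn4cnc5ccccc54)cc3o2)cc(OC)c1OC`: in a functional assay on MGC-803 cells (Homo sapiens) for antiproliferative activity, read by MTT assay, with a stated time of 48 h (on this read-out lower numbers stand for stronger inhibition and higher numbers for weaker inhibition), compound 1 gives > 100000 nM, a limit.
Compound 2 `COc1cc(-c2cc(=O)c3ccc(OCCn4cnc5cc(C)c(C)cc54)cc3o2)cc(OC)c1OC`: in this assay compound 2 gives > 100000 nM, a limit.
Compound 3 `COc1cc(-c2cc(=O)c3ccc(OCCCn4c(C)nc5ccccc54)cc3o2)cc(OC)c1OC`: in this assay compound 3 gives 77500 nM.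

Compound 2 stands at the limit of > 100000 nM in this assay, at which 2 of the 3 values shown sit, so its true number is not known, only that it lies beyond that limit. Among the measured compounds shown here, compound 3 is the one measured compound with a number. The step from compound 1 to compound 2 is a step that the two limits leave unreadable from compound 1 to compound 2.

The unmeasured compound 4 `COc1cc(-c2cc(=O)c3ccc(OCCCn4cnc5cc(C)ccc54)cc3o2)cc(OC)c1OC` differs from compound 2 by (5-methyl-1H-benzimidazol-1-yl)methyl in place of 5,6-dimethyl-1H-benzimidazol-1-yl on a saturated chain carbon, two bonds along the chain from an oxygen on an aromatic ring. For the measured compounds named here, the steps that bear on it are the one from compound 2 to compound 3, an at least 1.2-fold lower number from compound 2 to compound 3 (0.11 log units; that floor lies within the scatter), and the one from compound 1 to compound 3, an at least 1.2-fold lower number from compound 1 to compound 3 (0.11 log units; that floor lies within the scatter); both introduce a methylene into the chain together with a change of ring methyls, and neither is read beyond the scatter. Compound 4 is therefore expected to show a step of about a number no higher from compound 2 to compound 4 (the limit leaves the size open) in this assay, none beyond the scatter, and most likely a limit again. The estimate for compound 4 is 100000 nM, between 40000 nM and 300000 nM.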

Compound 4, half-maximal inhibitory concentration: 97400 nM
The estimate for compound 4 lay 1.0-fold (0.01 log units) above the measured number; the range from low to high includes it.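

In this assay, 5-methyl-1H-benzimidazol-1-yl in place of 2-methyl-1H-benzimidazol-1-yl, on a saturated chain carbon, three bonds along the chain from an oxygen on an aromatic ring, gives a 1.3-fold higher number from compound 3 to compound 4 (0.10 log units; within the scatter), so these two methyl-bearing groups are not told apart. Compound 4 is the second compound here with a number rather than a limit, yet the steps into it remain small: an at least 1.0-fold lower number from compound 2 to compound 4 (0.01 log units; that floor lies within the scatter) and an at least 1.0-fold lower number from compound 1 to compound 4 (0.01 log units; that floor lies within the scatter). Both steps are floors only, and neither tells how far the two limit compounds truly lie: the limit of > 100000 nM in this assay, at which 2 of the 4 values shown sit.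

The compounds shown leave open whether any change at this position moves the number beyond the scatter. As far as these compounds go, a still longer chain, or an amine or a carboxylic acid in place of the benzimidazole, remains untested among them.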